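The source may report more compounds than this note shows. Statements on the series, on what has been measured and on what is new or still open speak of the compounds shown alone.

Working notes on the series.

Compound 1 `CCCCN(CCCC)C(=O)CCCOC(=O)c1c(CC)nc(CCC)n1Cc1ccc(-c2ccccc2-c2nn[nH]n2)cc1` gives 500 nM in an assay on isolated protein for binding affinity to Type-2 angiotensin II receptor (Homo sapiens) (on this read-out higher numbers stand for weaker inhibition and lower numbers for stronger inhibition), the highest number among the three measured compounds. Among the measured compounds shown here, compound 2 `CCCc1nc(CC)c(C(=O)OCc2cccc(C(=O)c3ccccc3)c2)n1Cc1ccc(-c2ccccc2S(=O)(=O)NC(=O)OCCC(C)C)cc1F` gives 0.9 nM in this assay, and compound 3 `CCCc1nc(CC)c(C(=O)OCCN2C(=O)c3ccccc3C2=O)n1Cc1ccc(-c2ccccc2S(=O)(=O)NC(=O)OCCC(C)C)cc1F` gives 7 nM in this assay; both gaps to compound 1 lie beyond the scatter, and no single-point step connects them to compound 1.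

Compound 4 `CCCCN(Cc1ccccc1)C(=O)CCCOC(=O)c1c(CC)nc(CCC)n1Cc1ccc(-c2ccccc2-c2nn[nH]n2)cc1` differs from compound 1 by phenyl in place of propyl on a saturated chain carbon bound to an amide-type nitrogen. For the measured compounds named here, no measured pair shows this change, so its size is not anchored by the data. A modest move toward lower numbers is expected, estimated as a 2.0-fold lower number from compound 1 to compound 4 (0.30 log units; within the scatter). Compound 4 is therefore estimated at 250 nM in this assay, within the range 60 nM to 1500 nM.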

Compound 4, half-maximal inhibitory concentration: 300 nM
The estimate for compound 4 lay 1.2-fold (0.08 log units) below the measured number, and the stated range covers the measured number.
By their numbers in this assay, from the lowest: compound 2; then compound 3; then compounds 4 and 1 (each within the scatter of the next).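

Among the compounds shown here, the first single-point step, phenyl in place of propyl on a saturated chain carbon bound to an amide-type nitrogen, reads a 1.7-fold lower number from compound 1 to compound 4 (0.22 log units; within the scatter) in this assay for this pair. This position thus accepts a six-membered aromatic ring without a shift beyond the scatter. No evidence bearing on this result is available.

From the compounds shown here alone, whether an amine or a carboxylic acid in place of phenyl on this carbon would move the number beyond the scatter stays open. So does the effect of a longer chain there.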